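Methylsulfonyl to cyclopropylsulfonyl on compound 2

The source may report more compounds than this note shows. Statements on the series, on what has been measured and on what is new or still open speak of the compounds shown alone.

In a physicochemical assay for lipophilicity (on this read-out lower numbers stand for lower lipophilicity and higher numbers for higher lipophilicity), compound 2 `CCn1cnc2c(-c3ccc(F)c(-c4ccc(S(C)(=O)=O)cc4OC)c3)cnnc21` reads 2.5, within the scatter of compound 1 `CCn1cnc2c(-c3ccc(F)c(-c4cccc(C(=O)NC)c4)c3)cnnc21` at 2.8. For the measured compounds named here, these two values place compound 2 level with the only other measured compound. Compound 3 `CCn1cnc2c(-c3ccc(F)c(-c4ccc(S(=O)(=O)C5CC5)cc4OC)c3)cnnc21` carries cyclopropyl in place of methyl on a sulfonyl sulfur. Going by the values given here, no measured pair shows this change, so the expectation rests on the structural change alone. A modest upward step in this assay, just beyond the scatter, is expected: a number 0.40 log units higher from compound 2 to compound 3 (beyond the scatter). For compound 3 the estimated value is 2.9, with an expected range of 2.6 to 3.3.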

Compound 3, distribution coefficient: 2.7
For compound 3 the middle estimate is 0.20 log units above the measured one; low and high end bracket the measured number.
By their numbers in this assay, from the lowest: compounds 2, 3 and 1 (each within the scatter of the next).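

In this assay, for the compounds shown here, cyclopropyl in place of methyl on a sulfonyl sulfur gives a number 0.20 log units higher from compound 2 to compound 3 (within the scatter), the first step that differs in one place. This position therefore accepts the three-membered ring with a read-out that stays within the scatter of the methyl compound. Nothing at hand explains the size of this step. Open, on these data alone, is how an amine on the same sulfonyl sulfur, or a longer chain such as n-propyl, would read in this assay. Also open, as far as these compounds go, is whether the same change gives a similar step on another core.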